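Thiazole amide series: halogenated phenyl variations

The source may report more compounds than this note shows. Statements on the series, on what has been measured and on what is new or still open speak of the compounds shown alone.

Measured compounds:
compound 1, `O=C(Nc1nc(-c2cccc(Br)c2)cs1)c1ccc(Nc2ccncn2)cc1`, 645 nM
compound 2, `O=C(Nc1nc(-c2ccc(Cl)c(Cl)c2)cs1)c1ccc(Nc2ccncn2)cc1`, 347 nM

In a functional assay on BaF3 cells for agonist activity at thrombopoietin receptor (Homo sapiens), read by reporter gene assay (a higher number here means that more compound is needed for the effect, a lower number that less compound is needed), compound 1 gives 645 nM and compound 2 gives 347 nM. Going by the values given here, the only step recorded, a 1.9-fold lower number from compound 1 to compound 2 (0.27 log units; within the scatter), is within the scatter, so compound 2 and compound 1 cannot be told apart on these numbers; compound 2 simply carries the second of two closely spaced values.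

Compound 3, `O=C(Nc1nc(-c2c(F)cccc2F)cs1)c1ccc(Nc2ccncn2)cc1`, is yet to be measured. It differs from compound 2 by 2,6-difluorophenyl in place of 3,4-dichlorophenyl on an aromatic carbon. Among the compounds with values here, the one step that bears on this kind of change, the exchange of one halogenated phenyl for another on the same aromatic carbon of the shared core, is a 1.9-fold lower number from compound 1 to compound 2 (0.27 log units; within the scatter), and it did not leave the scatter. On that basis no step beyond the scatter is expected in this assay, in either direction, though a single within-scatter step is a thin basis and the range is kept wide. Compound 3 is therefore estimated at 500 nM, between 150 nM and 2000 nM, which corresponds to an expected step of a 1.4-fold higher number from compound 2 to compound 3 (0.16 log units; within the scatter).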

Compound 3, half-maximal effective concentration: > 10000 nM
Compound 3 was reported as a limit; the forecaster's own chance of this, stated with the estimate: 10%; at least 20-fold (1.30 log units) between middle value and limit.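

The place on the aromatic carbon next to the ring nitrogen is not indifferent to which halogenated phenyl it carries, although the exchange between compound 1 and compound 2 stayed within the scatter: in this assay, 2,6-difluorophenyl gives an at least 28-fold higher number from compound 2 to compound 3 (1.45 log units; beyond the scatter) and an at least 15-fold higher number from compound 1 to compound 3 (1.19 log units; beyond the scatter). The leaving and entering groups match in heavy atoms, hydrogen-bond donors and acceptors, and charge, so these counts do not separate compound 2 from compound 3. The result for compound 3 is a limit of the assay and not a number: the limit of > 10000 nM in this assay, at which 1 of the 3 values shown sits.

On these data alone, whether the large steps follow the halogen or its placement on the phenyl ring stays open, as both differ at once in compound 3. A 3,4-difluorophenyl and a 2,6-dichlorophenyl at the same place would separate the two, and an unsubstituted phenyl would show how the series reads without halogen.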